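A few compounds are considered here, and "the series" means these few. Any claim that something is new, unique, unknown or untested is made for them only; others in the source may bear on it.

Going by the values given here, the three compounds measured so far share one core and differ in the group on its aromatic carbon. Compound 1 `CC(C)(C)c1ccc(Oc2ccc3c(NCCCNCc4ccco4)ccnc3c2)cc1` gives 14500 nM in a physicochemical assay for solubility, with a stated time of 18 h, at pH 7.4; a lower number here means a less soluble compound, a higher number a more soluble compound. Compound 2 `CCC(CC)c1ccc2c(NCCCNCc3ccco3)ccnc2c1` gives 4200 nM, and compound 3 `c1ccc(Cc2ccc3c(NCCCNCc4ccco4)ccnc3c2)cc1` gives 4200 nM. Compound 3 thus stands level with compound 2, the two together at the low end of the three numbers, while compound 1 lies clearly higher. Among the compounds with values here, the one step measured within this set, no change at the digits printed from compound 2 to compound 3 (within the scatter), shows that swapping one hydrocarbon group for another left the solubility unchanged.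

Compound 4 `CN(C)c1cccc(Oc2ccc3c(NCCCNCc4ccco4)ccnc3c2)c1` is not yet measured. It differs from compound 3 in this way: 3-(dimethylamino)phenoxy in place of benzyl on an aromatic carbon. Within the data shown here, no measured step covers exactly this change. The closest guide is compound 1, which also carries an aryloxy group on that carbon and gives 14500 nM, higher than compound 3. Compound 4 is therefore expected to reach roughly that level or somewhat above it, with a 4.3-fold higher number from compound 3 to compound 4 (0.63 log units; beyond the scatter) as the expected step. The estimate for compound 4 in this assay is 18000 nM, within 6000 nM to 55000 nM.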

Compound 4, solubility: 14500 nM
Estimate against measurement, compound 4: 1.2-fold (0.09 log units) above, and the stated range covers the measured number.
By their numbers in this assay, from the lowest: compounds 2 and 3 (each within the scatter of the next); then compounds 1 and 4 (each within the scatter of the next).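

In this assay, 3-(dimethylamino)phenoxy on this aromatic carbon gives a 3.5-fold higher number from compound 3 to compound 4 (0.54 log units; beyond the scatter) and also a 3.5-fold higher number from compound 2 to compound 4 (0.54 log units; beyond the scatter), so the step up from the two compounds without an oxygen-linked ring is now seen with a second oxygen-linked group, not with compound 1 alone. Exchanging the ring on the oxygen, 3-(dimethylamino)phenyl in place of 4-(tert-butyl)phenyl, gives no change at the digits printed from compound 1 to compound 4 (within the scatter), so these two quite different rings read alike here. Nothing available explains these numbers.

The compounds shown do not separate the oxygen link from the ring it carries, and a plain phenoxy group, set against the benzyl of compound 3, would do that. Also open, as far as these compounds go, is how the number would respond to a carboxylic acid or a morpholine on that ring.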